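A few compounds are considered here, and "the series" means these few. Any claim that something is new, unique, unknown or untested is made for them only; others in the source may bear on it.

Working notes on the series.

The shared core carries a chloro group and a substituted benzyl arm bearing a chloromethyl group. Compound 1 `ClCc1cccc(Cn2cnc3c(Cl)ncnc32)c1` and compound 2 `ClCc1cccc(Cn2cnc3c(Cl)nc(Cl)nc32)c1` differ by one change, (chloro in place of hydrogen on an aromatic carbon). Compound 3 `ClCc1ccccc1Cn1cnc2ncnc(Cl)c21` is built of the same atoms as compound 1 joined differently; the difference between the two cores is not broken down here. Compound 4 `ClCc1ccccc1Cn1cnc2nc(Cl)nc(Cl)c21` stands to compound 3 as compound 2 stands to compound 1, the change being (chloro in place of hydrogen on an aromatic carbon), at a place described in the same words as for the first pair, so the two changes are the same.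

In a functional assay on NCI-H23 cells (Homo sapiens) for cytotoxicity, read by sulforhodamine B assay, with a stated time of 48 h (on this read-out lower numbers stand for higher toxicity in this test and higher numbers for lower toxicity in this test), compound 1 gives 8710 nM. In this assay compound 2 gives 22400 nM, so that the step is a 2.6-fold higher number from compound 1 to compound 2 (0.41 log units; beyond the scatter). In this assay compound 3 gives 49000 nM, the highest number of the three measured, with compound 2 nearest and compound 1 furthest, both gaps beyond the scatter. Compound 4 has not yet been measured in this assay.

The expectation for compound 4 rests on a single precedent: the step from compound 1 to compound 2 was a 2.6-fold higher number from compound 1 to compound 2 (0.41 log units; beyond the scatter), and the same change applied to compound 3 is expected to give a step of about a 2.2-fold higher number from compound 3 to compound 4 (0.35 log units; beyond the scatter). Since compound 3 already sits at the high end of the measured range, compound 4 is estimated at 110000 nM, with a plausible range from 50000 nM to 250000 nM; the result may fall outside the usable range and appear only as a limit.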

Compound 4, concentration lethal to 50% of the cells: 87100 nM
Compound 4: the middle estimate sits 1.3-fold (0.10 log units) above what was measured, within the range that was stated.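

In this assay, chloro in place of hydrogen on an aromatic carbon gives a 1.8-fold higher number from compound 3 to compound 4 (0.25 log units; within the scatter), so this step alone does not separate compound 3 from compound 4. Set beside the same change on the core of compound 1, the step shows no difference in size between the two cores, and the two results are compatible with the change carrying over from one core to the other: the same change on two cores in this assay, a 2.6-fold higher number (0.41 log units; beyond the scatter) from compound 1 to compound 2 and a 1.8-fold higher number (0.25 log units; within the scatter) from compound 3 to compound 4, 1.4-fold (0.16 log units) apart, within the scatter of two such steps. For the compounds shown here, this does not show that the change has a fixed size or a general direction, since the comparison rests on only two pairs of compounds, on one read-out and at one place, and only the step on the core of compound 1 lies beyond the scatter.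

The compounds shown leave open how groups other than hydrogen and chloro, such as an amine or a methoxy group, would read on the aromatic carbon between two ring nitrogen atoms. They also leave open what happens to these numbers when the chloromethyl group on the benzyl arm gives way to a methyl or a hydroxymethyl group.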